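Ethynyl for Vinyl on Two Fused Heteroaromatic Cores

The compounds below may be only part of what the source reports. "The series", "measured", "known", "first", "only" and "open" are said of these compounds alone.

Compound 1 `C=Cc1nc2ccccc2s1` and compound 2 `C#Cc1nc2ccccc2s1` share one core and differ at a single aromatic carbon: ethynyl in place of vinyl on an aromatic carbon. In a functional assay on NCI-H522 cells (Homo sapiens) for cytotoxicity, with a stated time of 3 days (a lower number here means a stronger inhibitor, a higher number a weaker inhibitor), compound 1 reaches only a limit, > 40000 nM. In this assay compound 2 gives 860 nM, so the change brings an at least 46-fold lower number from compound 1 to compound 2 (1.66 log units; beyond the scatter). Compound 3 `C=Cc1nc2ccccc2o1` carries a different core; the difference between the two cores is not broken down here. In this assay compound 3 likewise sits at a limit, > 40000 nM, which is the limit of > 40000 nM in this assay, at which 2 of the 3 values shown sit. Compound 4 `C#Cc1nc2ccccc2o1` has not been measured and stands to compound 3 as compound 2 stands to compound 1: ethynyl in place of vinyl on an aromatic carbon. The surroundings differ in that the ring here holds an oxygen where the ring of compound 1 holds a sulfur, so this is the same kind of change, not the same change. In this assay a step of about an at least 10-fold lower number from compound 3 to compound 4 (1.00 log units; beyond the scatter) is expected. That expectation rests on an at least 46-fold lower number from compound 1 to compound 2 (1.66 log units; beyond the scatter), which is itself only a bound, and on the other core carrying that effect across uncertainly. Compound 4 is estimated at 4000 nM, with a likely range from 600 nM to 40000 nM.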

Compound 4, half-maximal inhibitory concentration: 1260 nM
Compound 4: middle estimate off by 3.2-fold (0.50 log units), on the high side; measured number inside the range.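

In this assay the replacement of vinyl by ethynyl also lowers the number on the oxygen-containing core, with an at least 31-fold lower number from compound 3 to compound 4 (1.50 log units; beyond the scatter). Set beside the earlier step, the two compare as follows: the same change on two cores in this assay, an at least 46-fold lower number (1.66 log units; beyond the scatter) from compound 1 to compound 2 and an at least 31-fold lower number (1.50 log units; beyond the scatter) from compound 3 to compound 4; the limit leaves it open whether they differ. Compound 1 and compound 3 each stand at a limit rather than a true value, so the pair of steps shows that the direction of the change carries from one core to the other, but it does not show that the size carries over or how much the core contributes to it: the limit of > 40000 nM in this assay, at which 2 of the 4 values shown sit.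

The compounds shown leave open whether anything else at this place on the ring would serve as ethynyl does, such as a nitrile or a longer chain like propynyl. They also leave open how an amine or a carboxylic acid added elsewhere on either core would behave in this assay.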